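The source may hold more compounds than are shown below. What is called first, only, known or untested is meant among the compounds shown, and "the series" means these compounds.

Measured so far in a functional assay on HeLa cells (Homo sapiens) for cytotoxicity, read by MTT assay, with a stated time of 48 h; a lower number here means a stronger inhibitor, a higher number a weaker inhibitor:
- compound 1 `COc1ccc(-c2c3ccc4ccccc4c3nc3c2c(C)nc2c4ccccc4ccc32)cc1`: 45900 nM
- compound 2 `Cc1nc2c3ccccc3ccc2c2nc3c(ccc4ccccc43)c(-c3ccccc3S)c12`: 3190 nM
- compound 3 `Cc1nc2c3ccccc3ccc2c2nc3c(ccc4ccccc43)c(-c3ccc(O)cc3)c12`: 4630 nM

Compound 1 has the highest number of the three in this assay, and both gaps to it lie beyond the scatter: a 14-fold lower number from compound 1 to compound 2 (1.16 log units; beyond the scatter) and a 9.9-fold lower number from compound 1 to compound 3 (1.00 log units; beyond the scatter). Between compound 2 and compound 3 the gap is within the scatter, so no order is drawn between them: a 1.5-fold higher number from compound 2 to compound 3 (0.16 log units; within the scatter).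

Compound 4 `Cc1nc2c3ccccc3ccc2c2nc3c(ccc4ccccc43)c(C)c12` is not yet measured. Against compound 1 it differs in one place: methyl in place of 4-methoxyphenyl on an aromatic carbon. The change sits on the same aromatic carbon that carries the aryl group in compounds 1, 2 and 3, so the steps from compound 1 to compound 2 and from compound 1 to compound 3 bear on it; both lowered the number, one large, one modest. Neither of them, however, removes the aryl ring altogether, so they set only a loose guide. The expectation is therefore a lowering from compound 1 of uncertain size, possibly none beyond the scatter: the step expected from compound 1 to compound 4 is a 2.3-fold lower number from compound 1 to compound 4 (0.36 log units; beyond the scatter). For compound 4 the estimated value in this assay is 20000 nM, with a range from 5000 nM to 80000 nM.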

Compound 4, half-maximal inhibitory concentration: > 80000 nM
Compound 4: a limit, no number; the forecaster's own chance of this, stated with the estimate: 10%; middle value at least 4.0-fold (0.60 log units) from the limit.
By their numbers in this assay, from the lowest: compounds 2 and 3 (each within the scatter of the next); then compound 1. At a limit, above all of these: compound 4.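

Compound 4 gives no number in this assay, only a limit: the limit of > 80000 nM in this assay, at which 1 of the 4 values shown sits.

The earlier compounds shown here varied only the substituent on an aryl ring kept at this aromatic carbon, whereas methyl in place of that ring now gives large steps against the two compounds with the lower numbers (an at least 17-fold higher number from compound 3 to compound 4 (1.23 log units; beyond the scatter); an at least 25-fold higher number from compound 2 to compound 4 (1.39 log units; beyond the scatter)). Against compound 1 the step (an at least 1.7-fold higher number from compound 1 to compound 4 (0.24 log units; that floor lies within the scatter)) has a floor within the scatter, so the limit does not establish that methyl is worse than 4-methoxyphenyl at this carbon. Among the four compounds, the three with an aryl ring at this carbon give measured numbers and the one with methyl gives only a limit, while the substituent on that ring still moves the number, as compound 1 shows against compound 2 and compound 3.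

The compounds shown do not separate the loss of the ring itself from the effect of methyl as the replacement, and an unsubstituted phenyl, a 4-aminophenyl or a longer alkyl chain on this carbon would bear on that. They also leave open whether a group at the para position of the ring or one at the ortho position matters more, since 4-hydroxyphenyl and 2-sulfanylphenyl differ in both the atom and its place, and their values lie within the scatter of each other.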